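From Methoxy to Chloro on the Shared Core

The source may report more compounds than this note shows. Statements on the series, on what has been measured and on what is new or still open speak of the compounds shown alone.

Three compounds built on one shared core have been examined in an assay for inhibition of LL-diaminopimelate aminotransferase, chloroplastic (Arabidopsis thaliana); on this read-out lower numbers stand for stronger inhibition and higher numbers for weaker inhibition. Compound 1 `NN1C(=O)/C(=C/c2ccc(Cl)cc2)SC1=S` is recorded as "not active" (no number reported), so no number stands for it. Compound 2 `CCN1C(=O)/C(=C/c2ccc(Cl)cc2)SC1=S` gives 200000 nM in this assay. Compound 3 `COc1ccc(/C=C2\SC(=S)NC2=O)cc1` gives 142000 nM in this assay. These two numbers lie within the usual scatter of each other, so compound 3 and compound 2 cannot be told apart, and neither can be called the stronger inhibitor.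

Compound 4 `O=C1NC(=S)S/C1=C\c1ccc(Cl)cc1` has not yet been measured. It differs from compound 3 in one place: chloro in place of methoxy on an aromatic carbon. Going by the values given here, no pair of measured compounds isolates exactly this change, so there is no step to copy. The closest hint is compound 2, which also carries chloro on its aromatic ring but differs from compound 4 elsewhere, and which sits within the scatter of compound 3. On that basis the change from methoxy to chloro is expected to leave the number roughly where it is, with no direction beyond the scatter. The estimate for compound 4 in this assay is 150000 nM, with a range from 50000 nM to 450000 nM. This estimate means an expected step of a 1.1-fold higher number from compound 3 to compound 4 (0.02 log units; within the scatter), small enough to fall within the scatter.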

Compound 4, half-maximal inhibitory concentration: > 200000 nM
Compound 4: a limit, no number; the forecaster's own chance of this, stated with the estimate: 25%; middle value at least 1.3-fold (0.12 log units) away from the limit.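

Going by these compounds alone, this is the first direct reading of chloro in place of methoxy on this aromatic carbon, para to a group of 8 heavy atoms, with the rest of the molecule unchanged. In this assay the change gives an at least 1.4-fold higher number from compound 3 to compound 4 (0.14 log units; that floor lies within the scatter), so chloro brings no measurable gain in inhibition at this position, although the floor of that step does not separate the two compounds beyond the usual scatter, and the true size of the step may be larger. Compound 4 is recorded as a limit and not as a number: the limit of > 200000 nM in this assay, at which 1 of the 4 values shown sits.

The step that puts hydrogen in place of ethyl on the ring nitrogen gives a number no lower from compound 2 to compound 4 (the limit leaves the size open), so its size cannot be read and the role of that ethyl group remains unresolved. Also open, on these data alone, is whether a different group on the same aromatic carbon, such as an amine or a carboxylic acid, or a longer chain on the ring nitrogen, would bring the number in this assay clearly lower than anything seen on this shared core.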